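Two thiazolidinedione cores, one ether change, one prediction

A few compounds are considered here, and "the series" means these few. Any claim that something is new, unique, unknown or untested is made for them only; others in the source may bear on it.

The compounds share a thiazolidinedione head on an aryl ether, and they split into two cores: compound 1 `O=C1NC(=O)C(Cc2ccc(OCC3CC3)cc2)S1` and compound 3 `CCC(C)(C)Oc1ccc(CC2SC(=O)NC2=O)cc1` carry a saturated link between ring and head, while compound 2 `O=C1NC(=O)/C(=C/c2ccc(OCC3CC3)cc2)S1` and the unmeasured compound 4 `CCC(C)(C)Oc1ccc(/C=C2\SC(=O)NC2=O)cc1` carry an unsaturated link. The difference between the two cores is not broken down here.

In a functional assay on PC-12 cells (Rattus norvegicus) for inhibition, read by sulforhodamine B assay (a higher number here means a weaker inhibitor, a lower number a stronger inhibitor), compound 1 gives only a limit, > 100000 nM, which is the upper limit of the assay (the limit of > 100000 nM in this assay, at which 1 of the 3 values shown sits). In this assay compound 3 gives 23000 nM. The change from compound 1 to compound 3 is 1,1-dimethylpropyl in place of cyclopropylmethyl on an oxygen on an aromatic ring and it made a step of an at least 4.3-fold lower number from compound 1 to compound 3 (0.63 log units; beyond the scatter).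

In this assay compound 2 gives 23000 nM, which is level with the value of compound 3 at the digits shown, and the two lie within the scatter of each other.

Among the compounds with values here, compound 4 differs from compound 2 by 1,1-dimethylpropyl in place of cyclopropylmethyl on an oxygen on an aromatic ring, which is the same change, at the same place, as the one from compound 1 to compound 3. Because that earlier change gave an at least 4.3-fold lower number from compound 1 to compound 3 (0.63 log units; beyond the scatter), a step of similar direction is expected here, and the expected step from compound 2 to compound 4 is a 3.8-fold lower number from compound 2 to compound 4 (0.58 log units; beyond the scatter). Since the earlier step rests on a limit, its true size is uncertain, so the expectation is kept wide. Compound 4 is therefore expected to give about 6000 nM in this assay, most likely between 1500 nM and 25000 nM.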

Compound 4, half-maximal inhibitory concentration in the PC-12 assay: 15000 nM
The estimate for compound 4 lay 2.5-fold (0.40 log units) below the measured number, and the stated range covers the measured number.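

On the core of compound 2, putting 1,1-dimethylpropyl in place of cyclopropylmethyl gave in the PC-12 assay a 1.5-fold lower number from compound 2 to compound 4 (0.19 log units; within the scatter), so the change did not carry over from the saturated core at the size seen there: the same change on two cores in the PC-12 assay, an at least 4.3-fold lower number (0.63 log units; beyond the scatter) from compound 1 to compound 3 and a 1.5-fold lower number (0.19 log units; within the scatter) from compound 2 to compound 4, at least 2.8-fold (0.45 log units) apart, beyond the scatter of two such steps

Compound 1 stands at a limit of the assay and not at a number, so the earlier step has no known size, only a smallest one: the limit of > 100000 nM in the PC-12 assay, at which 1 of the 4 values shown sits.

The comparison therefore shows that this change cannot be transferred between the two cores at face value in this small set, but it gives no reason for the difference. In a physicochemical assay for lipophilicity (on this read-out higher numbers stand for higher lipophilicity and lower numbers for lower lipophilicity), compound 2 gives 1.99 and compound 4 gives 3.49, and this is the one other shift on record for the unsaturated core, a clear one: the measured partition coefficient of compound 2, 1.99, and of compound 4, 3.49, a number 1.50 log units higher (beyond the scatter)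

The compounds shown leave open whether the two cores would also part ways with other groups on the oxygen, such as a longer straight chain or a chain ending in an amine or a carboxylic acid. They also leave open how far the saturated and the unsaturated link differ in their own right, with the ether group held fixed.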